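This account rests on a few compounds, and the source may have more. Where it says the series, first, only, none or still open, it means among the compounds named here.

Working notes on the series. The shared core of compound 1 `N#CC1=C(N)N(c2ccc(S(N)(=O)=O)cc2)C2=C(CCCC2)C1c1ccccc1O` carries a 2-hydroxyphenyl group on a saturated ring carbon; in a functional assay on Ehrlich cells (Mus musculus) for cytotoxicity, read by trypan blue exclusion, with a stated time of 2 h, tested at 25 ug/mL (a higher number here means a stronger effect of the compound at the concentration tested, a lower number a weaker effect), compound 1 gives 40%. Compound 2 `N#CC1=C(N)N(c2ccc(S(N)(=O)=O)cc2)C2=C(CCCC2)C1c1ccc(O)cc1` carries a 4-hydroxyphenyl group at that position and gives 42% in this assay; compound 3 `N#CC1=C(N)N(c2ccc(S(N)(=O)=O)cc2)C2=C(CCCC2)C1/C=C/c1ccccc1` carries a 2-phenylethenyl group there and gives 70%. Compound 2 stands second highest of the three numbers: its nearest neighbour is compound 1 (a number 2 percentage points higher from compound 1 to compound 2 (within the scatter)), its furthest is compound 3 (a number 28 percentage points higher from compound 2 to compound 3 (beyond the scatter)). The step of a number 30 percentage points higher from compound 1 to compound 3 (beyond the scatter) points the same way.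

Compound 4 `N#CC1=C(N)N(c2ccc(S(N)(=O)=O)cc2)C2=C(CCCC2)C1c1cccc([N+](=O)[O-])c1` differs from compound 2 in one place: 3-nitrophenyl in place of 4-hydroxyphenyl on a saturated ring carbon. Among the measured compounds shown here, the only measured step that keeps an aromatic six-membered ring at this position, a number 2 percentage points higher from compound 1 to compound 2 (within the scatter), stayed within the scatter; the two steps beyond the scatter, a number 28 percentage points higher from compound 2 to compound 3 (beyond the scatter) and a number 30 percentage points higher from compound 1 to compound 3 (beyond the scatter), both concern the 2-phenylethenyl group and do not bear on a nitrophenyl. For the measured compounds named here, no measured compound carries a nitro group, so the direction of the change is open. The expectation for compound 4 in this assay is therefore a step of a number 3 percentage points higher from compound 2 to compound 4 (within the scatter), that is no change beyond the scatter. Compound 4 is estimated at 45%, with a range from 30% to 62%.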

Compound 4, a percentage reported as activity, at one concentration (the size of the read-out at that concentration, not a potency): 1%
For compound 4 the middle estimate is 44 percentage points above the measured one; measured number below the stated range.
By their numbers in this assay, from the lowest: compound 4; then compounds 1 and 2 (each within the scatter of the next); then compound 3.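

At this saturated ring carbon, the aromatic ring is not a neutral carrier: the step of a number 41 percentage points lower from compound 2 to compound 4 (beyond the scatter) and the step of a number 39 percentage points lower from compound 1 to compound 4 (beyond the scatter) show that the read-out responds strongly to what the phenyl ring bears, although the two hydroxyphenyl compounds alone gave no sign of this. With the step of a number 69 percentage points lower from compound 3 to compound 4 (beyond the scatter), this one position now spans almost the whole range seen in this assay, and compound 4 stands lowest of the four, beyond the scatter of every other compound. No measurement at hand accounts for the loss on moving to 3-nitrophenyl.

The compounds shown cannot separate the entry of the nitro group from the departure of the hydroxyl, nor the place of the substituent on the phenyl ring from its identity, since 3-nitrophenyl is the only group of its kind here. As far as these compounds go, whether a phenyl ring bearing an amine, a carboxylic acid or a methoxy group would read like compound 4 or like compound 2 remains open, as does whether the low number holds at other concentrations.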